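A Fluoro-to-Bromo Swap on a Weak Inhibitor

The source may report more compounds than this note shows. Statements on the series, on what has been measured and on what is new or still open speak of the compounds shown alone.

Measured compounds:
compound 1 `O/N=C(/Nc1cccc(Br)c1)c1ccc2occc2c1`, 1100 nM
compound 2 `OCc1cc2cc(/C(=N\O)Nc3cccc(Br)c3)ccc2o1`, 1200 nM
compound 3 `O/N=C(/Nc1cccc(F)c1)c1ccc2oc(COCC3CC3)cc2c1`, 8000 nM

In an assay on tissue (HeLa cells) for inhibition of Indoleamine 2,3-dioxygenase 1 (Homo sapiens), read by spectrophotometry (a lower number here means a stronger inhibitor, a higher number a weaker inhibitor), compound 3 stands highest of the three measured numbers. Compound 2 is nearest to it, and compound 1 furthest, both at a distance beyond the scatter. Compound 4 `O/N=C(/Nc1cccc(Br)c1)c1ccc2oc(COCC3CC3)cc2c1` has not been measured; it differs from compound 3 by bromo in place of fluoro on an aromatic carbon.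

Within the data shown here, only one measured step exists, a 1.1-fold higher number from compound 1 to compound 2 (0.04 log units; within the scatter), and it concerns a hydroxymethyl in place of hydrogen on the core, not the halogen swap. Compounds 1 and 2 do carry bromo, but each differs from compound 3 in more than one place, so their values do not isolate the change at hand. Among the measured compounds shown here, with no step that bears directly on it, the expectation rests on compound 3 alone, and the step is expected to be small, possibly a modest lowering of the number, with wide uncertainty a 2.0-fold lower number from compound 3 to compound 4 (0.30 log units; within the scatter). Compound 4 is therefore estimated at 4000 nM in this assay, within a range from 1500 nM to 11000 nM.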

Compound 4, half-maximal inhibitory concentration: 3200 nM
Estimate against measurement, compound 4: 1.3-fold (0.10 log units) above; the range from low to high includes it.
By their numbers in this assay, from the lowest: compounds 1 and 2 (each within the scatter of the next); then compound 4; then compound 3.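

In this assay, among these compounds, the change from 3-fluorophenyl to 3-bromophenyl gives a 2.5-fold lower number from compound 3 to compound 4 (0.40 log units; beyond the scatter), the first direct reading of this halogen swap at this place. With bromo held constant, adding the (cyclopropylmethoxy)methyl group gives a 2.9-fold higher number from compound 1 to compound 4 (0.46 log units; beyond the scatter), and placing cyclopropylmethyl on the oxygen of the hydroxymethyl group gives a 2.7-fold higher number from compound 2 to compound 4 (0.43 log units; beyond the scatter), so this substituent on the core changes the number where hydroxymethyl alone, in a 1.1-fold higher number from compound 1 to compound 2 (0.04 log units; within the scatter), did not. Nothing available here accounts for either effect.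

As far as these compounds go, whether the halogen swap would give a similar step on the core of compound 1 remains open. Also open, from the compounds shown here alone, is how chloro or methoxy would read at this place, or an amine or a carboxylic acid in place of the (cyclopropylmethoxy)methyl group.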